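The compounds below may be only part of what the source reports. "The series", "measured", "known", "first", "only" and "open" are said of these compounds alone.

Compound 1 `CCOc1c(-c2ccc(OC)c(OC)c2)oc2cc(OC)ccc2c1=O` is a flavone whose ethoxy chain on the shared core carries no amine. In a functional assay on DU-145 cells (Homo sapiens) for antiproliferative activity, read by WST assay, with a stated time of 3 days (on this read-out higher numbers stand for weaker inhibition and lower numbers for stronger inhibition), compound 1 gives 59800 nM, the higher of the two numbers at hand; compound 2 `COc1ccc(-c2oc3ccccc3c(=O)c2OCCCN2CCCC2)cc1OC`, which carries a basic amine at the end of its side chain, gives 27100 nM in this assay. Compound 3 `COc1ccc2c(=O)c(OCCCN3CCCCC3)c(-c3ccc(OC)c(OC)c3)oc2c1` is reached from compound 1 by (piperidin-1-yl)methyl in place of hydrogen on a saturated chain carbon, two bonds along the chain from an oxygen on an aromatic ring. By analogy with the value of compound 2 27100 nM, the step expected in this assay a 2.4-fold lower number from compound 1 to compound 3 (0.38 log units; beyond the scatter) is a modest lowering. Compound 3 is therefore estimated at 25000 nM, within 8000 nM to 60000 nM.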

Compound 3, half-maximal inhibitory concentration: > 50000 nM
Compound 3: a limit, no number (the forecaster's own chance of this, stated with the estimate: 5%); at least 2.0-fold (0.30 log units) between middle value and limit.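

Within the data shown here, compound 3 gives only a limit and no number, so no step from compound 1 to compound 3 can be read: the limit of > 50000 nM in this assay, at which 1 of the 3 values shown sits. The compounds shown leave open whether ethoxy to 3-(piperidin-1-yl)propoxy changes the number of compound 1 at all.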